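Working notes: the step from compound 3 to compound 4

The source may hold more compounds than are shown below. What is called first, only, known or untested is meant among the compounds shown, and "the series" means these compounds.

In a functional assay on MCF7 cells (Homo sapiens) for antiproliferative activity (on this read-out higher numbers stand for weaker inhibition of growth and lower numbers for stronger inhibition of growth), compound 1 `CC/C=C\[C@H](C)[C@H](OC(N)=O)[C@@H](C)[C@H](O)[C@@H](C)C/C(C)=C\[C@H](C)[C@@H](O)[C@@H](C)/C=C\[C@@H](O)C[C@H](O)[C@H](C)CO` gives 1000 nM, compound 2 `CC/C=C\[C@H](C)[C@H](OC(N)=O)[C@@H](C)[C@H](O)[C@@H](C)C/C(C)=C\[C@H](C)[C@@H](O)[C@@H](C)/C=C\[C@@H](O)C[C@@H]1OC(=O)[C@H](C)C[C@H]1C` gives 5.8 nM and compound 3 `CC/C=C\[C@H](C)[C@H](OC(N)=O)[C@@H](C)[C@H](O)[C@@H](C)C/C(C)=C\[C@H](C)[C@@H](O)[C@@H](C)/C=C\[C@@H](O)C[C@@H]1OC(=O)NC[C@H]1C` gives 110 nM, the middle of the three numbers. Compound 4 `CC/C=C\[C@H](C)[C@H](OC(N)=O)[C@@H](C)[C@H](O)[C@@H](C)C/C(C)=C\[C@H](C)[C@@H](O)[C@@H](C)/C=C\[C@@H](O)C[C@@H]1OC(=O)[C@H](C)[C@@H](O)[C@H]1C` differs from compound 3 as follows: a group of 10 heavy atoms (7 carbon, 3 oxygen; one six-membered non-aromatic ring with 1 hetero atom) in place of a group of 8 heavy atoms (5 carbon, 1 nitrogen, 2 oxygen; one six-membered non-aromatic ring with 2 hetero atoms), on a saturated chain carbon, two bonds along the chain from a double-bonded chain carbon and an oxygen on a saturated carbon. The closest measured guide is the large step of a 19-fold higher number from compound 2 to compound 3 (1.28 log units; beyond the scatter), where a ring with 2 hetero atoms replaces a ring with 1 hetero atom, the reverse of the exchange here. The large step of a 170-fold lower number from compound 1 to compound 2 (2.24 log units; beyond the scatter) and the modest step of a 9.1-fold lower number from compound 1 to compound 3 (0.96 log units; beyond the scatter) also bear on it. A sizeable fall beyond the scatter is expected in this assay, and the expected step is a 7.3-fold lower number from compound 3 to compound 4 (0.87 log units; beyond the scatter). For compound 4 the estimate is 15 nM, with an expected range of 4 nM to 60 nM.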

Compound 4, concentration for 50% growth inhibition: 6.2 nM
The estimate for compound 4 lay 2.4-fold (0.38 log units) above the measured number, and the stated range covers the measured number.
By their numbers in this assay, from the lowest: compounds 2 and 4 (each within the scatter of the next); then compound 3; then compound 1.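

In this assay hydroxy in place of hydrogen on a saturated ring carbon gives a 1.1-fold higher number from compound 2 to compound 4 (0.03 log units; within the scatter) and so places compound 2 and compound 4 within the scatter of each other. The hydroxy-bearing ring with 1 hetero atom matches the earlier ring with 1 hetero atom in its steps, with an 18-fold lower number from compound 3 to compound 4 (1.25 log units; beyond the scatter) against the ring with 2 hetero atoms and a 160-fold lower number from compound 1 to compound 4 (2.21 log units; beyond the scatter) against the open chain. No measurement shown here accounts for these steps. Open, as far as these compounds go, is whether an amine or a methoxy group on that ring carbon would also stay within the scatter of compound 2.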